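A few compounds are considered here, and "the series" means these few. Any claim that something is new, unique, unknown or untested is made for them only; others in the source may bear on it.

Of the compounds shown here, three sharing one core have been measured in a functional assay on the whole organism for inhibition, with Rattus norvegicus as the target, at a dose of 0.3 mg/kg by the oral route; on this read-out lower numbers stand for a weaker effect and higher numbers for a stronger effect at the one dose given. Compound 1 `Cc1ccc(-c2cc(Cl)cc(C(=O)Nc3nn[nH]n3)n2)cc1` gives 10%. Compound 2 `COc1cc(C(=O)Nc2nn[nH]n2)nc(-c2ccc(C)cc2)c1` gives in this assay 16%. Compound 3 `Cc1ccc(-c2cccc(C(=O)Nc3nn[nH]n3)n2)cc1` gives in this assay 21%, the highest of the three numbers; its gap to compound 2 is within the scatter, while the step of a number 11 percentage points higher from compound 1 to compound 3 (beyond the scatter) lies beyond it.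

Compound 4 `CCc1cc(C(=O)Nc2nn[nH]n2)nc(-c2ccc(C)cc2)c1` has not yet been measured. It differs from compound 3 in one place: ethyl in place of hydrogen on an aromatic carbon. Two measured steps end in compound 3 with a hydrogen on that carbon and so bear on the change: a number 11 percentage points higher from compound 1 to compound 3 (beyond the scatter) and a number 5 percentage points higher from compound 2 to compound 3 (within the scatter). Read the other way round, putting chloro or methoxy on that carbon in place of hydrogen cost a modest amount or nothing beyond the scatter. Ethyl is a third group entering the same carbon, and nothing measured shows how it behaves there. On these numbers a small loss, or no change beyond the scatter, is expected, and the estimated step is a number 7 percentage points lower from compound 3 to compound 4 (within the scatter). Compound 4 is therefore expected to give in this assay about 14%, with a range from 3% to 27%.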

Compound 4, a percentage reported as inhibition, in the whole organism at one dose (the size of the read-out at that dose, not a potency): 33%
Compound 4: the middle estimate sits 19 percentage points below what was measured, and the stated range ends below it.
By their numbers in this assay, from the lowest: compounds 1, 2 and 3 (each within the scatter of the next, the first and the last beyond it); then compound 4.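

In this assay, neither chloro nor methoxy on the carbon opposite the ring nitrogen had stood beyond the scatter above hydrogen, but ethyl does, with a number 12 percentage points higher from compound 3 to compound 4 (beyond the scatter) as the first measured gain at this position. The position therefore does not simply lose effect whenever hydrogen is replaced, and the result depends on which group enters: ethyl in place of methoxy gives a number 17 percentage points higher from compound 2 to compound 4 (beyond the scatter) and ethyl in place of chloro gives a number 23 percentage points higher from compound 1 to compound 4 (beyond the scatter) as the largest step in the set. Nothing at hand accounts for why ethyl differs from chloro and methoxy at this carbon.

The compounds shown leave open whether the gain continues with a longer chain such as propyl, survives branching as in isopropyl, or is lost with an amine or a carboxylic acid on the same carbon. They also leave open whether the order seen at this one oral dose holds at other doses, as each number gives the size of the effect at that dose and not a potency.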